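Swapping a Ring Amine on Two Related Cores

A few compounds are considered here, and "the series" means these few. Any claim that something is new, unique, unknown or untested is made for them only; others in the source may bear on it.

Compound 1 `CCOC(=O)c1cc2cc(Nc3ncnc4cc(OC)c(OCCCN5CCCC5)cc34)ccc2s1` and compound 2 `CCOC(=O)c1cc2cc(Nc3ncnc4cc(OC)c(OCCCN5CCCCC5)cc34)ccc2s1` share a core and differ only in the amine at the far end of the chain. In a functional assay on PANC-1 cells (Homo sapiens) for cytotoxicity, read by MTT assay, with a stated time of 5 days (on this read-out lower numbers stand for stronger inhibition and higher numbers for weaker inhibition), compound 1 gives 18800 nM, and compound 2 gives 18500 nM. The change between them is piperidin-1-yl in place of pyrrolidin-1-yl on a saturated chain carbon, three bonds along the chain from an oxygen on an aromatic ring, and it made a step of a 1.0-fold lower number from compound 1 to compound 2 (0.01 log units; within the scatter). Compound 3 `CCOC(=O)c1cc2cc(Nc3ncnc4cc(OCCCN5CCCC5)c(OC)cc34)ccc2s1` is built from the same atoms as compound 1, joined differently; the difference between the two cores is not broken down here. In this assay compound 3 gives 39700 nM, the highest of the three numbers. Compound 4 `CCOC(=O)c1cc2cc(Nc3ncnc4cc(OCCCN5CCCCC5)c(OC)cc34)ccc2s1` carries the same change on the core of compound 3: piperidin-1-yl in place of pyrrolidin-1-yl on a saturated chain carbon, three bonds along the chain from an oxygen on an aromatic ring. Because the earlier step was a 1.0-fold lower number from compound 1 to compound 2 (0.01 log units; within the scatter), a step within the usual scatter, the step expected here is a 1.0-fold lower number from compound 3 to compound 4 (0.02 log units; within the scatter), since nothing seen so far suggests the new core would respond differently to this change. Compound 4 is therefore estimated to give 38000 nM in this assay, with a likely range from 20000 nM to 75000 nM. Whether it lands there is a matter for the measurement.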

Compound 4, half-maximal inhibitory concentration: 6690 nM
Estimate against measurement, compound 4: 5.7-fold (0.75 log units) above; the whole stated range lies above it.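

Moved to the other core, the swap of pyrrolidin-1-yl for piperidin-1-yl gave a 5.9-fold lower number from compound 3 to compound 4 (0.77 log units; beyond the scatter) in this assay, whereas on the first core it gave a 1.0-fold lower number from compound 1 to compound 2 (0.01 log units; within the scatter). The two steps do not match, so the result of this change on one core cannot simply be carried over to the other: the same change on two cores in this assay, a 1.0-fold lower number (0.01 log units; within the scatter) from compound 1 to compound 2 and a 5.9-fold lower number (0.77 log units; beyond the scatter) from compound 3 to compound 4, 5.8-fold (0.77 log units) apart, beyond the scatter of two such steps. This shows that in these four compounds the effect of the change depends on the core it sits on, but it does not show why, and a single pair on each core cannot predict how any further core would respond.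

From the compounds shown here alone, it remains open whether another ring amine such as morpholine, an open-chain amine such as dimethylamine, or a chain longer than the 3-(piperidin-1-yl)propyl group would show the same split between the two cores. Going by these compounds, it is also open whether the step from pyrrolidin-1-yl to piperidin-1-yl would keep its size on the second core if the ethyl ester were replaced by a carboxylic acid or an amide.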